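The compounds below may be only part of what the source reports. "The series", "measured", "known", "first", "only" and "open" are said of these compounds alone.

Working notes on the series. All three measured compounds share the core of compound 1 `O=C(N/N=C/c1cccc(F)c1)c1cccnc1Nc1cccc(C(F)(F)F)c1` and differ only in the aryl ring on the carbon with a double bond to nitrogen. Within the data shown here, in a functional assay on the whole organism (strain Wistar) for inhibition, with Rattus norvegicus as the target, read by paw edema, with a stated time of 1 h, at a dose of 10 mg/kg by the intraperitoneal route (on this read-out lower numbers stand for less inhibition and higher numbers for more inhibition at the one dose given (going by the name of the read-out)), compound 1 gives 51.5%, the second highest of the three numbers so far. Compound 2 `O=C(N/N=C/c1ccc(F)cc1)c1cccnc1Nc1cccc(C(F)(F)F)c1` gives 43.2%, and compound 3 `O=C(N/N=C/c1ccc(O)cc1)c1cccnc1Nc1cccc(C(F)(F)F)c1` gives 70.5% in this assay. The step of a number 8.3 percentage points lower from compound 1 to compound 2 (within the scatter) lies within the scatter, whereas a number 19 percentage points higher from compound 1 to compound 3 (beyond the scatter) and a number 27.3 percentage points higher from compound 2 to compound 3 (beyond the scatter) both lie beyond it.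

Compound 4 `COc1cccc(/C=N/NC(=O)c2cccnc2Nc2cccc(C(F)(F)F)c2)c1` is the next to be measured in this assay. Against compound 1 the change is methoxy in place of fluoro on an aromatic carbon. Among the measured compounds shown here, no measured step brings a methoxy onto this ring. For the measured compounds named here, the only step that exchanges a fluoro for an oxygen-bearing group, a number 27.3 percentage points higher from compound 2 to compound 3 (beyond the scatter), is modest and upward, but it concerns hydroxy on a 4-hydroxyphenyl ring rather than methoxy on a 3-methoxyphenyl ring, so it bears only loosely. For compound 4 a step of a number 5.5 percentage points higher from compound 1 to compound 4 (within the scatter) is expected, a small rise that may not clear the scatter. The estimate for compound 4 in this assay is 57%, with a range from 42% to 72%.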

Compound 4, a percentage reported as inhibition, in the whole organism at one dose (the size of the read-out at that dose, not a potency): 58.8%
For compound 4 the middle estimate is 1.8 percentage points below the measured one; measured number inside the range.
By their numbers in this assay, from the lowest: compounds 2, 1 and 4 (each within the scatter of the next, the first and the last beyond it); then compound 3.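

In this assay, methoxy and fluoro on an aromatic carbon of this ring, meta to a large group, are not told apart (a number 7.3 percentage points higher from compound 1 to compound 4 (within the scatter)). The 3-methoxyphenyl ring does stand apart from both rings with a group in the 4-position, above the 4-fluorophenyl ring (a number 15.6 percentage points higher from compound 2 to compound 4 (beyond the scatter)) and below the 4-hydroxyphenyl ring (a number 11.7 percentage points lower from compound 3 to compound 4 (beyond the scatter)), so an oxygen-bearing group on this ring does not by itself give the highest number in the series. Nothing at hand gives a cause for these differences.

The compounds shown leave open whether the gap between compound 3 and compound 4 follows the group or its place on the ring, as the two changes come together in that step. Also open, going by these compounds, is how an amine or a carboxylic acid on this ring would read in this assay.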